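Extending the carboxamide substituent on a triazole series

The source may report more compounds than this note shows. Statements on the series, on what has been measured and on what is new or still open speak of the compounds shown alone.

Measured compounds:
compound 1, `COc1ccc(-n2nc(C(N)=O)nc2-c2cc(OC)c(OC)c(OC)c2)cc1`, 64%
compound 2, `CNC(=O)c1nc(-c2cc(OC)c(OC)c(OC)c2)n(-c2ccc(OC)cc2)n1`, 50%

Among the compounds with values here, compound 2 stands at the lower of the two numbers in a functional assay on the whole organism for inhibition, with Rattus norvegicus as the target, read by paw edema, with stated times of 30 min and 5 h, at a dose of 0.28 mmol/kg by the oral route; a lower number here means less inhibition, a higher number more inhibition at the dose given (going by the name of the read-out); compound 1 sits higher, and the one counted step, a number 14 percentage points lower from compound 1 to compound 2 (beyond the scatter), is the only guide. Compound 3, `CCNC(=O)c1nc(-c2cc(OC)c(OC)c(OC)c2)n(-c2ccc(OC)cc2)n1`, carries methyl in place of hydrogen on a saturated chain carbon bound to an amide-type nitrogen. That step bears on it only loosely, since it sits one bond further out, so a smaller fall or none beyond the scatter is expected. Compound 3 is therefore estimated at 44%, between 28% and 60%, meaning an expected a number 6 percentage points lower from compound 2 to compound 3 (within the scatter).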

Compound 3, a percentage reported as inhibition, in the whole organism at one dose (the size of the read-out at that dose, not a potency): 52%
Beside the measured number, compound 3's estimate is 8 percentage points below it, within the range that was stated.
By their numbers in this assay, from the lowest: compounds 2 and 3 (each within the scatter of the next); then compound 1.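

In this assay, extending methyl to ethyl on the amide-type nitrogen gives a number 2 percentage points higher from compound 2 to compound 3 (within the scatter), so the extra carbon on this chain does not separate the two compounds as the first substitution did. Ethyl in place of the amide hydrogen gives a number 12 percentage points lower from compound 1 to compound 3 (beyond the scatter), which leaves compound 1, with its unsubstituted carboxamide, apart from both substituted amides. No supporting data bear on why the chain extension leaves the read-out unresolved.

The compounds shown leave open whether a longer chain, such as propyl or butyl, would stay within the same range. They also leave open how a carboxylic acid in place of the carboxamide would read.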